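Benzylthio variation in a sulfonylguanidine pyrazole series

A few compounds are considered here, and "the series" means these few. Any claim that something is new, unique, unknown or untested is made for them only; others in the source may bear on it.

For the measured compounds named here, the two compounds measured so far share one core and differ at the sulfanyl-bearing benzyl group and in the arrangement of the guanidine. Compound 1 `Cc1cc(S(=O)(=O)/N=C(\N)n2nccc2-c2ccccc2)c(SCc2ccc(Cl)cc2)cc1Cl` gives 7000 nM in a functional assay on HCT-116 cells (Homo sapiens) for cytotoxicity, read by MTT assay, with a stated time of 72 h; on this read-out lower numbers stand for stronger inhibition and higher numbers for weaker inhibition. Compound 2 `Cc1cc(-c2ccccc2)n(/C(N)=N/S(=O)(=O)c2cc(C)c(Cl)cc2SCc2ccccc2C)n1` stands at the higher of the two numbers, with 42000 nM in this assay; the gap between the two lies beyond the usual scatter, but the two structures differ in more than one place, so no single step can be read from them.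

Compound 3 `Cc1cc(-c2ccccc2)n(/C(N)=N/S(=O)(=O)c2cc(C)c(Cl)cc2SCc2cccc3ccccc23)n1` is not yet measured. It differs from compound 2 in one place: naphthalen-1-yl in place of 2-methylphenyl on a saturated chain carbon bound to a sulfur. Going by the values given here, nothing among the measured pairs isolates this kind of change, so the expected step from compound 2 to compound 3 rests on the change alone. A small movement toward a lower number in this assay is expected, though one that may well stay within the scatter; the expected step is a 1.7-fold lower number from compound 2 to compound 3 (0.23 log units; within the scatter). Compound 3 is therefore estimated at 25000 nM in this assay, with a range from 8000 nM to 80000 nM.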

Compound 3, half-maximal inhibitory concentration: 7000 nM
Compound 3: the middle estimate sits 3.6-fold (0.55 log units) above what was measured; measured number outside the range, below it.
By their numbers in this assay, from the lowest: compounds 1 and 3 (each within the scatter of the next); then compound 2.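

In this assay, for the compounds shown here, the saturated chain carbon bound to a sulfur now gives the first single-place comparison: naphthalen-1-yl in place of 2-methylphenyl gives a 6.0-fold lower number from compound 2 to compound 3 (0.78 log units; beyond the scatter) in this modest step. The read-out at this position therefore depends on the group carried there, and the group with 2 six-membered aromatic rings and 10 heavy atoms goes with the lower number in this pair. The data offer no measurement that accounts for the step.

This one pair sets no trend, and it leaves open whether the lower number follows the second aromatic ring, the larger carbon count or the loss of the 2-methylphenyl group itself. Phenyl, naphthalen-2-yl, pyridin-3-yl or a longer chain carrying an aromatic ring at this same place, with the rest of compound 2 unchanged, would help separate these readings and show how far the response at this position extends.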